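A few compounds are considered here, and "the series" means these few. Any claim that something is new, unique, unknown or untested is made for them only; others in the source may bear on it.

Measured so far:
compound 1 `O=C(O)c1ccc(C=C2CCN(C(=O)C(c3ccccc3)c3ccccc3)CC2)c(F)c1`: 2%
compound 2 `O=C(O)Cc1ccc(C=C2CCN(C(=O)C(C3CCCCC3)C3CCCCC3)CC2)cc1`: 6%

Both were tested in an assay for inhibition of 3-oxo-5-alpha-steroid 4-dehydrogenase 1 (Homo sapiens), tested at 10 uM; on this read-out higher numbers stand for more inhibition at the one concentration tested (going by the name of the read-out) and lower numbers for less inhibition. Compound 1 gives 2%, the lowest of the two numbers, while compound 2 gives 6%, a number within the usual scatter of it, so the two cannot be told apart. Compound 3 `O=C(O)c1ccc(C=C2CCN(C(=O)C(c3ccccc3)c3ccccc3)CC2)cc1` is compound 1 with one change: hydrogen in place of fluoro on an aromatic carbon. Among the compounds with values here, no measured pair shows this change, so nothing is known about its effect here. Compound 3 is expected to stay close to compound 1, with a step of a number 2 percentage points higher from compound 1 to compound 3 (within the scatter) that is not beyond the scatter. The estimate for compound 3 is 4%, with a range from -6% to 16%.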

Compound 3, a percentage reported as inhibition, at one concentration (the size of the read-out at that concentration, not a potency): 26%
For compound 3 the middle estimate is 22 percentage points below the measured one, and the stated range ends below it.
By their numbers in this assay, from the lowest: compounds 1 and 2 (each within the scatter of the next); then compound 3.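

In this assay putting hydrogen in place of fluoro gives a number 24 percentage points higher from compound 1 to compound 3 (beyond the scatter) and shows that this single ring position, ortho to a large group and meta to a carboxy group, can change the read-out. Earlier, the two values could not be told apart, so no such change had been seen. Nothing measured here explains the step.

Still open, on these data alone, is how a chlorine atom, a methyl group or an amine would read at this position. As far as these compounds go, whether removing fluoro has a similar effect on another core also remains unknown.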